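The source may report more compounds than this note shows. Statements on the series, on what has been measured and on what is new or still open speak of the compounds shown alone.

In an ADME assay on 2209-23 cells (Homo sapiens) for cytotoxicity, read by WST assay (on this read-out lower numbers stand for higher toxicity in this test and higher numbers for lower toxicity in this test), compound 3, whose structure is `CS(=O)(=O)Nc1ccc2c(c1)S(=O)(=O)C=C(c1c(O)c3cc(F)ccc3n(Cc3ccccn3)c1=O)N2`, gives > 50000 nM, which is a limit of the assay and not a measured number. Compound 1, with the structure `CS(=O)(=O)Nc1ccc2c(c1)S(=O)(=O)C=C(c1c(O)c3cc(F)ccc3n(Cc3ccc(F)cc3)c1=O)N2`, gives > 50000 nM in the same test, again a limit. Compound 2, built as `COc1cc(Cn2c(=O)c(C3=CS(=O)(=O)c4cc(NS(C)(=O)=O)ccc4N3)c(O)c3cc(F)ccc32)ccc1F`, likewise gives > 50000 nM, also a limit. All three values therefore sit at the same limit, (the limit of > 50000 nM in this assay, at which 3 of the 3 values shown sit), so the steps between them cannot be read: from compound 1 to compound 2 the step is a step that the two limits leave unreadable from compound 1 to compound 2, from compound 1 to compound 3 it is a step that the two limits leave unreadable from compound 1 to compound 3, and from compound 2 to compound 3 it is a step that the two limits leave unreadable from compound 2 to compound 3. Compound 4, whose structure is `CS(=O)(=O)Nc1ccc2c(c1)S(=O)(=O)C=C(c1c(O)c3cc(F)ccc3n(CC3CCCCC3)c1=O)N2`, differs from compound 3 by one change: cyclohexyl in place of pyridin-2-yl on a saturated chain carbon bound to an aromatic nitrogen. Within the data shown here, no measured step gives a readable size for this kind of change, and every value seen so far is a limit. For compound 4 the outcome is therefore expected to stay at the limit, with the step of a number no higher from compound 3 to compound 4 (the limit leaves the size open) expected to be none beyond the scatter. The estimate for compound 4 in this assay is 50000 nM, between 20000 nM and 120000 nM.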

Compound 4, half-maximal cytotoxic concentration: > 50000 nM
Compound 4: only a limit was reported; the forecaster's own chance of this, stated with the estimate: 80%; the middle value sits exactly at the limit.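

Compound 4 also gives only a limit and not a number, like compound 1, compound 2 and compound 3, so no step between it and any of them can be read: the limit of > 50000 nM in this assay, at which 4 of the 4 values shown sit.

The compounds shown leave open how far apart these four truly lie in this assay, and whether changing the group on the saturated chain carbon bound to an aromatic nitrogen alters the result at all.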